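The compounds below may be only part of what the source reports. "The series", "measured", "known", "first", "only" and "open" are said of these compounds alone.

In a functional assay on MCF7 cells (Homo sapiens) for antiproliferative activity, read by MTT assay, with a stated time of 48 h (a higher number here means a weaker inhibitor, a lower number a stronger inhibitor), compound 1 `Clc1ccc(-c2nn(-c3ccccc3)cc2-c2nc3cc(Br)ccc3[nH]2)cc1` gives 1920 nM and compound 3 `COc1ccc(-c2nn(-c3ccccc3)cc2-c2nc3cc(Br)ccc3[nH]2)cc1` gives 1830 nM with no difference beyond the scatter, while compound 2 `O=C(OCc1ccccc1)c1ccc2[nH]c(-c3cn(-c4ccccc4)nc3-c3ccc(Cl)cc3)nc2c1` gives 13900 nM as a clearly higher number. Compound 3 therefore stands level with compound 1 and well under compound 2. The next compound is compound 4 `COc1ccc(-c2nn(-c3ccccc3)cc2-c2nc3cc(C(=O)OCc4ccccc4)ccc3[nH]2)cc1`, which differs from compound 3 by benzyloxycarbonyl in place of bromo on an aromatic carbon on the shared core. The same exchange, benzyloxycarbonyl in place of bromo on an aromatic carbon, has one precedent in a 7.2-fold higher number from compound 1 to compound 2 (0.86 log units; beyond the scatter) as a modest step beyond the scatter. The other measured step, a 1.0-fold lower number from compound 1 to compound 3 (0.02 log units; within the scatter) for methoxy in place of chloro, stays within the scatter and suggests that the methoxy compound may follow the chloro one. On this single precedent, a step of similar size toward a higher number is expected in this assay and is estimated as a 6.6-fold higher number from compound 3 to compound 4 (0.82 log units; beyond the scatter) for this change. Compound 4 is expected at 12000 nM with an estimated range from 5000 nM to 30000 nM in this assay.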

Compound 4, half-maximal inhibitory concentration: 7460 nM
For compound 4 the middle estimate is 1.6-fold (0.21 log units) above the measured one; the range from low to high includes it.
By their numbers in this assay, from the lowest: compounds 3 and 1 (each within the scatter of the next); then compounds 4 and 2 (each within the scatter of the next).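

In this assay, going by these compounds alone, benzyloxycarbonyl in place of bromo on this aromatic carbon again raises the number, a 4.1-fold higher number from compound 3 to compound 4 (0.61 log units; beyond the scatter), so the exchange now has a second core on which its direction and size can be checked: the same change on two cores in this assay, a 7.2-fold higher number (0.86 log units; beyond the scatter) from compound 1 to compound 2 and a 4.1-fold higher number (0.61 log units; beyond the scatter) from compound 3 to compound 4, 1.8-fold (0.25 log units) apart, within the scatter of two such steps Methoxy in place of chloro, earlier seen only with bromo on the core, now also stays within the scatter with benzyloxycarbonyl at this position, a 1.9-fold lower number from compound 2 to compound 4 (0.27 log units; within the scatter), and the two readings agree: the same change on two cores in this assay, a 1.0-fold lower number (0.02 log units; within the scatter) from compound 1 to compound 3 and a 1.9-fold lower number (0.27 log units; within the scatter) from compound 2 to compound 4, 1.8-fold (0.25 log units) apart, within the scatter of two such steps Across these four compounds, the exchange at this position therefore reads much the same with either chloro or methoxy in the other place.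

The compounds shown carry only bromo and benzyloxycarbonyl on this carbon, so they cannot separate the contribution of the carbonyl from that of the benzyl ring. On these data alone, how a carboxylic acid, a methyl ester or an amine would read there in this assay remains open.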